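The source may report more compounds than this note shows. Statements on the series, on what has been measured and on what is new or still open speak of the compounds shown alone.

Measured compounds and their values in a functional assay on A-431 cells (Homo sapiens) for cytotoxicity, read by MTT assay, with a stated time of 48 h; a lower number here means a stronger inhibitor, a higher number a weaker inhibitor:

Compound 1 `CCCCCCCCCCCCCCNC(=O)[C@@H](NC(=O)c1cccs1)[C@@H](C)O`: 26500 nM
Compound 2 `CCCCCCCCCCCCCCNC(=O)[C@@H](NC(=O)/C=C/c1ccccc1)[C@@H](C)O`: 64900 nM
Compound 3 `CCCCCCCCCCCCCCCCCCNC(=O)[C@@H](NC(=O)c1cccs1)[C@@H](C)O`: 33300 nM

Compound 3 stands second highest of these three numbers; its gap to compound 1 and its gap to compound 2 both lie within the scatter. Compound 4 `CCCCCCCCCCCCCCCCCCNC(=O)[C@@H](NC(=O)/C=C/c1ccccc1)[C@@H](C)O` is not yet measured. It differs from compound 3 in one place: 2-phenylethenyl in place of thiophen-2-yl on a carbonyl carbon. The same exchange has been measured once before, on the shorter chain, where it gave a 2.4-fold higher number from compound 1 to compound 2 (0.39 log units; beyond the scatter), a modest step beyond the scatter. The chain lengthening itself, a 1.3-fold higher number from compound 1 to compound 3 (0.10 log units; within the scatter), stayed within the scatter. A step of about the same modest size towards a higher number is therefore expected here, a 2.4-fold higher number from compound 3 to compound 4 (0.38 log units; beyond the scatter). Compound 4 is estimated at 80000 nM, within a range from 40000 nM to 160000 nM.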

Compound 4, half-maximal inhibitory concentration: 177000 nM
The estimate for compound 4 lay 2.2-fold (0.34 log units) below the measured number; measured number outside the range, above it.
By their numbers in this assay, from the lowest: compounds 1, 3 and 2 (each within the scatter of the next, the first and the last beyond it); then compound 4.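

Exchanging thiophen-2-yl for 2-phenylethenyl on the carbonyl carbon also raises the number on the longer chain (a 5.3-fold higher number from compound 3 to compound 4 (0.73 log units; beyond the scatter)), so the direction of this change now holds on two cores, and the sizes of the two steps do not differ beyond the scatter: the same change on two cores in this assay, a 2.4-fold higher number (0.39 log units; beyond the scatter) from compound 1 to compound 2 and a 5.3-fold higher number (0.73 log units; beyond the scatter) from compound 3 to compound 4, 2.2-fold (0.34 log units) apart, within the scatter of two such steps.
The chain lengthening, within the scatter with thiophen-2-yl, gives a step beyond it with 2-phenylethenyl (a 2.7-fold higher number from compound 2 to compound 4 (0.44 log units; beyond the scatter)), though that gap also stays within the scatter: the same change on two cores in this assay, a 1.3-fold higher number (0.10 log units; within the scatter) from compound 1 to compound 3 and a 2.7-fold higher number (0.44 log units; beyond the scatter) from compound 2 to compound 4, 2.2-fold (0.34 log units) apart, within the scatter of two such steps.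
Open, going by these compounds, is how a chain longer than that of compound 4 would read, and how an amine in place of thiophen-2-yl on the carbonyl carbon would read.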